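Cyano in Place of Hydrogen on the Core of Compound 1

The source may report more compounds than this note shows. Statements on the series, on what has been measured and on what is new or still open speak of the compounds shown alone.

Compound 1 `CC(=O)NCc1cccc(Cn2nc(NS(=O)(=O)c3ccc(Cl)s3)c3ccccc32)c1` gives 251 nM in a functional assay on CHO cells for antagonist activity at C-C chemokine receptor type 4 (Homo sapiens), read by GTPgammaS binding (on this read-out higher numbers stand for weaker inhibition and lower numbers for stronger inhibition), the highest of the three numbers in hand. Compound 2 `CC(=O)NCc1cccc(Cn2nc(NS(=O)(=O)c3ccc(Cl)s3)c3c(Cl)cccc32)c1` gives 31.6 nM and compound 3 `CC(=O)NCc1cccc(Cn2nc(NS(=O)(=O)c3ccc(Cl)s3)c3c(O)cccc32)c1` gives 12.6 nM. Compound 4 `CC(=O)NCc1cccc(Cn2nc(NS(=O)(=O)c3ccc(Cl)s3)c3c(C#N)cccc32)c1` differs from compound 1 by cyano in place of hydrogen on an aromatic carbon. Both measured changes at this same aromatic carbon lowered the number: a 7.9-fold lower number from compound 1 to compound 2 (0.90 log units; beyond the scatter), and a 20-fold lower number from compound 1 to compound 3 (1.30 log units; beyond the scatter). Between the two substituted compounds, a 2.5-fold lower number from compound 2 to compound 3 (0.40 log units; beyond the scatter). For the measured compounds named here, on this basis a lower number is expected for compound 4 too, though no step with cyano has been measured, so its size stays uncertain. Compound 4 is therefore estimated at 40 nM in this assay, with a range from 10 nM to 160 nM, an expected step of a 6.3-fold lower number from compound 1 to compound 4 (0.80 log units; beyond the scatter).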

Compound 4, half-maximal inhibitory concentration: 316 nM
Beside the measured number, compound 4's estimate is 7.9-fold (0.90 log units) below it; the measured number lies above the stated range.
By their numbers in this assay, from the lowest: compound 3; then compound 2; then compounds 1 and 4 (each within the scatter of the next).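

At this aromatic carbon, cyano brings no gain over hydrogen, the step being a 1.3-fold higher number from compound 1 to compound 4 (0.10 log units; within the scatter) and so inside the scatter. The lowering seen with chloro and hydroxy therefore does not hold for every group placed here, as a 10-fold higher number from compound 2 to compound 4 (1.00 log units; beyond the scatter) and a 25-fold higher number from compound 3 to compound 4 (1.40 log units; beyond the scatter) show. Nothing in hand explains this difference between the groups.

As far as these compounds go, whether fluoro, methoxy or an amine at this same carbon would follow hydroxy and chloro, or would instead follow cyano, stays open. The compounds shown also leave open whether these differences persist when other parts of the molecule change.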